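Thioether series: from dimethoxyphenyl to dimethylphenyl

The compounds below may be only part of what the source reports. "The series", "measured", "known", "first", "only" and "open" are said of these compounds alone.

Compound 1 `COc1ccc(SCc2ccc(/C=C/C(=O)Nc3ccccc3N)cc2)cc1OC` stands lowest of the two measured numbers: in a functional assay on HeLa cells (Homo sapiens) for inhibition, read by CCK-8 assay, with a stated time of 72 h, tested at 2 uM (a higher number here means more inhibition of growth at the concentration tested, a lower number less inhibition of growth), compound 1 gives 10.1%. Compound 2 `Nc1ccccc1NC(=O)c1ccc(CSc2nccc(C(F)(F)F)n2)cc1` has a different core, and in this assay compound 2 gives 68.3%, a gap beyond the scatter. Compound 3 `Cc1cc(C)cc(SCc2ccc(/C=C/C(=O)Nc3ccccc3N)cc2)c1` is not yet measured; it differs from compound 1 in one place: 3,5-dimethylphenyl in place of 3,4-dimethoxyphenyl on a sulfur. Within the data shown here, no step between measured compounds is available for this change, so only a small step, if any, is expected, with no clear direction beyond the scatter. The expected step is a number 4.9 percentage points higher from compound 1 to compound 3 (within the scatter). For compound 3 the estimate in this assay is 15%, between 0% and 40%.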

Compound 3, percent growth inhibition at one concentration: 11.7%
Estimate against measurement, compound 3: 3.3 percentage points above, and the stated range covers the measured number.
By their numbers in this assay, from the lowest: compounds 1 and 3 (each within the scatter of the next); then compound 2.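

In this assay, among these compounds, 3,5-dimethylphenyl in place of 3,4-dimethoxyphenyl on a sulfur gives a number 1.6 percentage points higher from compound 1 to compound 3 (within the scatter), the first direct reading at this position. The entering group has 0 hydrogen-bond acceptors against 2 in the leaving group, and this exchange leaves the read-out within the scatter. No evidence on hand bears on this result.

Still open, going by these compounds, is whether an amine or a carboxylic acid on this aromatic ring would move the number beyond the scatter. The same question applies to a longer chain on the sulfur in place of the ring.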